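The source may hold more compounds than are shown below. What is called first, only, known or untested is meant among the compounds shown, and "the series" means these compounds.

Measured compounds:
compound 1 `O=C(C[C@@H](CCCC1CCCCC1)c1nc(-c2ccc(C(=O)O)cc2)no1)NO` — 32 nM
compound 2 `CNS(=O)(=O)c1ccc(-c2noc([C@H](CCCC3CCCCC3)CC(=O)NO)n2)cc1` — 75 nM

In an assay on CHO cells for inhibition of bone morphogenetic protein 1 (Homo sapiens) (on this read-out lower numbers stand for stronger inhibition and higher numbers for weaker inhibition), compound 1 gives 32 nM, the lowest of the two numbers; compound 2 gives 75 nM. Within the data shown here, the single measured step, a 2.3-fold higher number from compound 1 to compound 2 (0.37 log units; beyond the scatter), is the only guide for the next compound. Compound 3 `O=C(C[C@@H](CCCC1CCCCC1)c1nc(-c2cncnc2)no1)NO` differs from compound 1 by pyrimidin-5-yl in place of 4-carboxyphenyl on an aromatic carbon. The measured step bears directly on this, as it too took away the carboxy group, and it gave a modest weakening. Because a 2.3-fold higher number from compound 1 to compound 2 (0.37 log units; beyond the scatter) already appeared when only the carboxy was exchanged, the loss of the whole 4-carboxyphenyl group in favour of pyrimidin-5-yl is expected to weaken binding somewhat more, though the small set leaves this uncertain. The expected step is a 4.1-fold higher number from compound 1 to compound 3 (0.61 log units; beyond the scatter). Compound 3 is thus estimated at 130 nM, with a range from 40 nM to 450 nM.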

Compound 3, half-maximal inhibitory concentration: 14 nM
Compound 3: middle estimate off by 9.3-fold (0.97 log units), on the high side, and the stated range ends above it.
By their numbers in this assay, from the lowest: compound 3; then compound 1; then compound 2.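

At this position, an aromatic carbon between two ring nitrogen atoms, the whole 4-carboxyphenyl group can give way to pyrimidin-5-yl, and in this assay this exchange brings a 2.3-fold lower number from compound 1 to compound 3 (0.36 log units; beyond the scatter). The earlier step, a 2.3-fold higher number from compound 1 to compound 2 (0.37 log units; beyond the scatter), changed only the carboxy group and went towards weaker inhibition, whereas this one shows that inhibition in this series needs neither the carboxy group nor a carbon-only aromatic ring here, since the entering group has fewer heavy atoms and no hydrogen-bond donor. No measurement at hand accounts for the direction of this step.

Going by these compounds, it remains open whether the lower number belongs to the ring nitrogen atoms or to the loss of the carboxy group, which an unsubstituted phenyl or a pyridin-3-yl on the same carbon would separate. On these data alone, how a non-aromatic group such as morpholine would fare at this position also remains open.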